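The source may hold more compounds than are shown below. What is called first, only, known or untested is meant among the compounds shown, and "the series" means these compounds.

For the measured compounds named here, compound 1 `O=C(NC[C@@H]1CCCC[C@H]1O)NC1CCN(Cc2ccn(-c3ccc(C(F)(F)F)cc3)c2)CC1` holds the highest number of the two measured so far: in an assay on HEK293 cells for displacement of a labelled ligand from melanin-concentrating hormone receptor 1 (Homo sapiens) (a higher number here means a weaker inhibitor, a lower number a stronger inhibitor), compound 1 gives 46 nM. Compound 2 `O=C(NC1CCN(Cc2ccn(-c3ccc(C(F)(F)F)cc3)c2)CC1)N1CCn2cccc2C1c1ccccc1` gives in this assay 10 nM, a lower number than compound 1 by a margin beyond the scatter. Compound 3 `O=C(NC[C@H]1CCCC[C@H]1O)NC1CCN(Cc2ccn(-c3ccc(C(F)(F)F)cc3)c2)CC1` is next in this assay; its difference from compound 1: the two compounds have the same atoms and bonds and differ only in configuration as drawn: 1 of 2 stereo elements differ; a stereocentre at a saturated ring carbon is drawn S in compound 1 and R in compound 3. Going by the values given here, no measured pair shows what this change does, so the step from compound 1 to compound 3 in this assay is expected to be modest, near the scatter, with a slight lean toward a higher number. The estimate for compound 3 in this assay is 70 nM, range 20 nM to 250 nM, an expected step of a 1.5-fold higher number from compound 1 to compound 3 (0.18 log units; within the scatter).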

Compound 3, half-maximal inhibitory concentration: 63 nM
Compound 3: middle estimate off by 1.1-fold (0.05 log units), on the high side; measured number inside the range.
By their numbers in this assay, from the lowest: compound 2; then compounds 1 and 3 (each within the scatter of the next).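

In this assay, changing the saturated ring carbon from S to R gives a 1.4-fold higher number from compound 1 to compound 3 (0.14 log units; within the scatter). In this single pair, the configuration at that stereocentre has no effect that can be told from the scatter. The comparison is clean, and the step can be assigned to this one change: the fact that compounds 1 and 3 differ only in the configuration as drawn.

As far as these compounds go, the role of the second stereo element remains open, as the pair keeps it unchanged. Also open, from the compounds shown here alone, is how the number responds when the hydroxyl on that ring gives way to an amine or a carboxylic acid.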